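Amine variation on the fused tetracyclic quinone core

The source may report more compounds than this note shows. Statements on the series, on what has been measured and on what is new or still open speak of the compounds shown alone.

Measured so far in a functional assay on MCF7 cells (Homo sapiens) for inhibition, read by sulforhodamine B assay; a higher number here means a weaker inhibitor, a lower number a stronger inhibitor:
- compound 1 `O=C1C(NC2CC2)=CC(=O)c2c1nc1n2[C@H]2OC[C@@H](O)[C@H]2OC1`: > 16000 nM, a limit of the assay
- compound 2 `O=C1C=C(NC2CCCC2)C(=O)c2c1nc1n2[C@H]2OC[C@@H](O)[C@H]2OC1`: > 16000 nM, likewise a limit
- compound 3 `CCCc1ccc(NC2=CC(=O)c3nc4n(c3C2=O)[C@H]2OC[C@@H](O)[C@H]2OC4)cc1`: 4660 nM

Compound 1 stands at the limit of this assay, with no number of its own. Compound 2 sits at the same limit. Going by the values given here, compound 3 alone gives a number, and the one measured step, an at least 3.4-fold lower number from compound 2 to compound 3 (0.53 log units; beyond the scatter), shows that replacing a small cycloalkyl group on the amine nitrogen by 4-propylphenyl moves the series out of the limit region; the limit of > 16000 nM in this assay, at which 2 of the 3 values shown sit, is where the two cycloalkyl amines remain.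

The next compound, compound 4 `CCCN(CCC)C1=CC(=O)c2c(nc3n2[C@H]2OC[C@@H](O)[C@H]2OC3)C1=O`, differs from compound 1 thus: dipropylamino in place of cyclopropylamino on a double-bonded ring carbon. Among the compounds with values here, no measured step exchanges one alkylamine for another, and the one step known concerns an aryl amine, so it bears on compound 4 only loosely: it shows that a change on this nitrogen can reach a measurable number, but it gives no reason to expect the same from a second alkyl-type substituent. Both alkyl amines measured so far sit at the limit.

Compound 4 is therefore expected to remain at or near the limit, with no step beyond the scatter: a step that the limit leaves unreadable from compound 1 to compound 4. The estimate for compound 4 is 20000 nM, between 8000 nM and 50000 nM.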

Compound 4, half-maximal inhibitory concentration: > 16000 nM
Compound 4: a limit, no number; the forecaster's own chance of this, stated with the estimate: 65%; the middle value does not contradict the limit.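

Compound 4 gives > 16000 nM, a limit and not a number. Compound 1 also stands at a limit, so no step can be read between compound 1 and compound 4. The compounds shown leave open how far these alkyl amines lie from the limit, and whether aryl amines other than the 4-propylphenyl amine of compound 3 also give a number.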